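The source may report more compounds than this note shows. Statements on the series, on what has been measured and on what is new or still open speak of the compounds shown alone.

Measured in a functional assay on A2780 cells (Homo sapiens) for inhibition, read by sulforhodamine B assay, with a stated time of 72 h; on this read-out higher numbers stand for weaker inhibition and lower numbers for stronger inhibition:
- compound 1 `O=C(NCc1ccc(S(=O)(=O)c2ccccc2)cc1)c1ccc2ncncc2c1`, a limit of the assay rather than a number: > 10000 nM
- compound 2 `O=C(NCc1ccc(S(=O)(=O)c2ccccc2)cc1)c1cc2ccncc2s1`: 14 nM
- compound 3 `O=C(NCc1ccc(S(=O)(=O)N2CCCCC2)cc1)c1cc2cnccc2o1`: 1500 nM

Compound 2 gives the lowest of the two numbers in this assay; compound 3 sits well higher, a gap beyond the usual scatter. Compound 1 reports only a limit of this assay (the limit of > 10000 nM in this assay, at which 1 of the 3 values shown sits). Compound 4 `O=C(NCc1ccc(S(=O)(=O)c2ccccc2)cc1)c1cc2cnccc2[nH]1` is not yet measured. It differs from compound 2 on the carbonyl carbon: a group of 9 heavy atoms (7 carbon, 2 nitrogen; one five-membered aromatic ring with 1 hetero atom, one six-membered aromatic ring with 1 hetero atom) in place of a group of 9 heavy atoms (7 carbon, 1 nitrogen, 1 sulfur; one five-membered aromatic ring with 1 hetero atom, one six-membered aromatic ring with 1 hetero atom), on a carbonyl carbon. Among the measured compounds shown here, no measured pair in the set changes at this position alone, so the size of the step is not known from data; compound 1 and compound 3, which differ from compound 2 at this position and elsewhere, both sit above compound 2 in this assay. For compound 4 a modest rise in the number is expected, a 4.3-fold higher number from compound 2 to compound 4 (0.63 log units; beyond the scatter), at or a little beyond the scatter. The estimate for compound 4 is 60 nM, expected to fall between 10 nM and 500 nM.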

Compound 4, half-maximal inhibitory concentration: 18 nM
The estimate for compound 4 lay 3.3-fold (0.52 log units) above the measured number; the measured number falls inside the stated range.
By their numbers in this assay, from the lowest: compounds 2 and 4 (each within the scatter of the next); then compound 3. At a limit, above all of these: compound 1.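

In this assay, the exchange on the carbonyl carbon gives the first step read at this position alone, a 1.3-fold higher number from compound 2 to compound 4 (0.11 log units; within the scatter), so sulfur in the five-membered aromatic ring can give way to nitrogen without a change beyond the scatter. The entering group carries 1 hydrogen-bond donor and the leaving group 0, and in this pair that difference comes with no separation in the numbers, something compound 1 and compound 3 could not show, as each differs from compound 2 at this position and elsewhere. Nothing measured here gives a cause for this result.

Open, on these data alone, is how a methyl group in place of the hydrogen on the ring nitrogen of compound 4, or an amine or a carboxylic acid on its rings, would move the number. Also open, as far as these compounds go, is whether the same exchange stays within the scatter when another group sits on the sulfonyl.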